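Liver microsome half-lives, compounds 1 to 3

A few compounds are considered here, and "the series" means these few. Any claim that something is new, unique, unknown or untested is made for them only; others in the source may bear on it.

Measured so far:
compound 1 `NS(=O)(=O)c1cc(-c2nnc(CN3CCN(Cc4ccccc4)CC3)o2)c(Cl)cc1SCc1ccccc1` gives 0.08 h in an ADME assay on microsomes from liver (Homo sapiens) for metabolic stability, read by LC-MS, using NADPH, tested at 5 uM; a higher number here means that the compound lasts longer, a lower number that the compound disappears faster
compound 2 `CC(C)(O)c1cn(Cc2nnc(-c3cc(S(N)(=O)=O)c(SCc4ccccc4)cc3Cl)o2)nn1` gives 0.23 h in this assay

Compound 2 stands highest of the two numbers in this assay; compound 1 sits lower, and that gap lies beyond the usual scatter. Compound 3 `NS(=O)(=O)c1cc(-c2nnc(/C=C/c3ccc(Cl)cc3)o2)c(Cl)cc1SCc1ccccc1` differs from compound 2 by 2-(4-chlorophenyl)ethenyl in place of (4-(1-hydroxy-1-methylethyl)-1H-1,2,3-triazol-1-yl)methyl on an aromatic carbon. For the measured compounds named here, no measured pair isolates this change, so the expectation rests on compound 2 alone and on both values being short. The step from compound 2 to compound 3 is expected to be a decrease of modest size, a 1.9-fold lower number from compound 2 to compound 3 (0.28 log units; within the scatter), roughly at the edge of the scatter. Compound 3 is estimated at 0.12 h, with a range from 0.04 h to 0.35 h.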

Compound 3, half-life: 0.207 h
Estimate against measurement, compound 3: 1.7-fold (0.24 log units) below, within the range that was stated.
By their numbers in this assay, from the lowest: compound 1; then compounds 3 and 2 (each within the scatter of the next).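

At this position on the shared core, 2-(4-chlorophenyl)ethenyl in place of (4-(1-hydroxy-1-methylethyl)-1H-1,2,3-triazol-1-yl)methyl gives a 1.1-fold lower number from compound 2 to compound 3 (0.05 log units; within the scatter) in this assay. The entering group carries no hydrogen-bond donors or acceptors and a six-membered aromatic ring of carbon only, yet the half-lives remain within the scatter of each other. No available evidence explains this result. Going by these compounds, whether a carboxylic acid or a simple methyl at this position would also leave the half-life unchanged remains open. So does whether any group here can lengthen it.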